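Carbamate series: trifluoromethyl analogue of compound 2

The source may report more compounds than this note shows. Statements on the series, on what has been measured and on what is new or still open speak of the compounds shown alone.

Measured so far:
- compound 1 `Cc1ccccc1NC(=O)OC(CCN(C)C)c1ccc(Cl)cc1`: 3890 nM
- compound 2 `COc1ccc(NC(=O)OC(CCN(C)C)c2ccc(Cl)cc2)cc1`: 1660 nM

Among the compounds with values here, in an assay on NIH3T3 cells with Urotensin-2 receptor (Homo sapiens) as the target (on this read-out lower numbers stand for an effect already at smaller amounts and higher numbers for an effect only at larger amounts of compound), compound 2 holds the lowest of the two numbers; its only neighbour is compound 1, and the step of a 2.3-fold lower number from compound 1 to compound 2 (0.37 log units; beyond the scatter) exchanged the aryl group on the carbamate nitrogen. Compound 3 `CN(C)CCC(OC(=O)Nc1ccc(C(F)(F)F)cc1)c1ccc(Cl)cc1` is not yet measured. It differs from compound 2 by trifluoromethyl in place of methoxy on an aromatic carbon, placed para to a large group. Within the data shown here, only the single step bears on this change, and it concerned a different exchange, so the guide is weak. A modest improvement is expected, a 1.7-fold lower number from compound 2 to compound 3 (0.22 log units; within the scatter), with wide uncertainty. Compound 3 is estimated at 1000 nM, range 300 nM to 3500 nM.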

Compound 3, half-maximal effective concentration: 251 nM
Beside the measured number, compound 3's estimate is 4.0-fold (0.60 log units) above it; the whole stated range lies above it.
By their numbers in this assay, from the lowest: compound 3; then compound 2; then compound 1.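

In this assay the group on this aromatic carbon, para to a large group, matters on its own: trifluoromethyl in place of methoxy gives a 6.6-fold lower number from compound 2 to compound 3 (0.82 log units; beyond the scatter) and leaves compound 3 with the lowest of the three numbers. The earlier step exchanged the whole aryl group, whereas this one keeps the place fixed and changes only the group on it. Nothing measured here accounts for the size of this step.

Open, going by these compounds, is whether a nitrile or a chlorine in the same place gives a number close to that of compound 3. Also open, on these data alone, is whether the trifluoromethyl step holds up with a pyrrolidine in place of the dimethylamine end of the chain.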